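The source may report more compounds than this note shows. Statements on the series, on what has been measured and on what is new or still open speak of the compounds shown alone.

Working notes on the series. Compound 1 `COc1cccc([S+]([O-])c2cccc(N)c2C#N)c1` is taken as the reference for its core; in a functional assay on MT4 cells (Homo sapiens) for cytotoxicity (on this read-out higher numbers stand for weaker inhibition and lower numbers for stronger inhibition), compound 1 gives a value that is a limit of the assay, > 80000 nM. Compound 2 `Cc1cccc([S+]([O-])c2cccc(N)c2C#N)c1` carries methyl in place of methoxy on an aromatic carbon and in this assay compound 2 also gives a limit, > 200000 nM. The size of a step that the two limits leave unreadable from compound 1 to compound 2 cannot be read, due to the limit of > 200000 nM in this assay, at which 1 of the 3 values shown sits, and (the limit of > 80000 nM in this assay, at which 1 of the 3 values shown sits). Compound 3 `COc1ccccc1S(=O)(=O)c1cccc(N)c1C#N` rests on a different core; the difference between the two cores is not broken down here. In this assay compound 3 gives 146000 nM. Compound 4 `Cc1ccccc1S(=O)(=O)c1cccc(N)c1C#N` carries the same kind of change, (methyl in place of methoxy on an aromatic carbon), the place here being ortho to a large group rather than meta. Among the compounds with values here, with the earlier step unreadable, the step is expected to be small, a 1.0-fold higher number from compound 3 to compound 4 (0.01 log units; within the scatter), because the only number in hand is that of compound 3 at 146000 nM. Compound 4 is thus estimated at 150000 nM, likely between 50000 nM and 400000 nM.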

Compound 4, half-maximal inhibitory concentration: > 200000 nM
Compound 4 gave a limit, no number; the forecaster's own chance of this, stated with the estimate: 40%; middle value at least 1.3-fold (0.12 log units) from the limit.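

In this assay, as far as these compounds go, methyl in place of methoxy on an aromatic carbon gives an at least 1.3-fold higher number from compound 3 to compound 4 (0.13 log units; that floor lies within the scatter) on the core of compound 3, and compound 4 gives a limit, so the full size of this step stays unknown. On the core of compound 1 the same kind of change cannot be read, so this shows no agreement or disagreement between the two cores. The change therefore cannot be said to carry over or to fail to carry over, because limits dominate the values shown: the limit of > 200000 nM in this assay, at which 2 of the 4 values shown sit.

From the compounds shown here alone, what an amine or a carboxylic acid in that place would give remains open. So does the size of the methyl for methoxy change on either core where both partners give numbers.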